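Cytotoxicity limits and the (3-phenylpropyl)amino change

This account rests on a few compounds, and the source may have more. Where it says the series, first, only, none or still open, it means among the compounds named here.

In a functional assay on HEK293 cells (Homo sapiens) for cytotoxicity (a lower number here means that less compound is tolerated, a higher number that more compound is tolerated), compound 1 (`COc1ccc([C@H]2CC(=O)N(c3cccc(C)c3)C2)cc1OC1CCCC1`) gives > 10000 nM as a limit. Compound 2 (`COc1ccc([C@H]2CC(=O)N(c3cccc([S+](C)[O-])c3)C2)cc1OC1CCCC1`) gives > 10000 nM as a limit too, so it has no number of its own. Both values sit at the same limit (the limit of > 10000 nM in this assay, at which 2 of the 2 values shown sit). Within the data shown here, the one measured step (a step that the two limits leave unreadable from compound 1 to compound 2) has no readable size to carry forward. Compound 3 (`COc1ccc([C@H]2CC(=O)N(c3cccc(NCCCc4ccccc4)c3)C2)cc1OC1CCCC1`) differs from compound 2 (a group of 10 heavy atoms (9 carbon, 1 nitrogen; one six-membered aromatic ring of carbon only) in place of a group of 3 heavy atoms (1 carbon, 1 oxygen, 1 sulfur; no ring), on an aromatic carbon), with (3-phenylpropyl)amino entering meta to a large group. No direction can be read, and the expected step (a step that the limit leaves unreadable from compound 2 to compound 3) lies within the scatter in this assay. For compound 3 the estimate is 15000 nM with an expected range from 4000 nM to 50000 nM if a number is reported, though another limit is more likely.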

Compound 3, half-maximal cytotoxic concentration: > 10000 nM
Compound 3 ended at the assay's limit (the forecaster's own chance of this, stated with the estimate: 75%); the middle value lies beyond the limit too.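

Compound 1, compound 2 and compound 3 all stand at a limit in this assay, so no step among them can be read: the limit of > 10000 nM in this assay, at which 3 of the 3 values shown sit.

On these data alone, whether any group at this place on the shared core gives a readable cytotoxic concentration stays open.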